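This account rests on a few compounds, and the source may have more. Where it says the series, first, only, none or still open, it means among the compounds named here.

Values measured in a functional assay on A-375 cells (Homo sapiens) for antiproliferative activity, read by MTT assay, with a stated time of 72 h; a lower number here means a stronger inhibitor, a higher number a weaker inhibitor:

- Compound 1 `O=C1COc2ccc(-c3cnc(Cl)c(NS(=O)(=O)c4ccc(F)cc4)c3)cc2N1c1ccc(F)cc1`: > 40000 nM
- Compound 2 `COc1cccc(N2C(=O)COc3ccc(-c4cccc(NS(=O)(=O)c5ccc(F)cc5)c4)cc32)c1`: > 40000 nM

Each entry is a limit of the assay and not a number.

Compound 2 reads > 40000 nM, which is a limit. Its place on the scale is therefore known only through (the limit of > 40000 nM in this assay, at which 2 of the 2 values shown sit). No true potency can be read for compound 2, and no ranking of the two measured compounds is possible.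

The next compound, compound 3 `O=C1COc2ccc(-c3cccc(NS(=O)(=O)c4ccc(F)cc4)c3)cc2N1C1CC1`, keeps the rest of compound 2 and puts cyclopropyl in place of 3-methoxyphenyl on an amide-type nitrogen in a ring. Among the compounds with values here, no pair of measured compounds differs in just one place, so the data offer no earlier step to serve as a guide. In this assay, no change beyond the usual scatter is expected, and no direction can be favoured. The expected outcome is a number no higher from compound 2 to compound 3 (the limit leaves the size open). Another reading at the limit would be the most likely result.

For compound 3 the estimated value is 40000 nM, with an expected range from 12000 nM to 100000 nM.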

Compound 3, half-maximal inhibitory concentration: > 40000 nM
Compound 3 was reported as a limit (the forecaster's own chance of this, stated with the estimate: 70%); the middle value sits exactly at the limit.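

In this assay compound 3 gives > 40000 nM as a limit of the assay and not a number. Within the data shown here, compound 2 also reads as a limit, so no step from compound 2 to compound 3 can be read: the limit of > 40000 nM in this assay, at which 3 of the 3 values shown sit. Within this assay the compounds shown leave open the true potency of each, and so what any single change of group does to it.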